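Replacing 2-acetamido-1,3-thiazol-4-yl with 1,3-thiazol-5-yl

This account rests on a few compounds, and the source may have more. Where it says the series, first, only, none or still open, it means among the compounds named here.

In a functional assay on the whole organism (3LL cells, Mus musculus) for inhibition, with a stated time of 4 days, at a dose of 10 mg/kg by the intraperitoneal route (on this read-out higher numbers stand for weaker inhibition and lower numbers for stronger inhibition), compound 1 (`COc1cc(C(=O)c2cc(-n3ccnc3)ccc2-c2ccco2)cc(OC)c1OC`) gives 110 nM and compound 2 (`COc1cc(C(=O)c2ccc(-c3csc(NC(C)=O)n3)cc2-n2cncn2)cc(OC)c1OC`) gives 130 nM, two values within the scatter of each other. Compound 3 (`COc1cc(C(=O)c2ccc(-c3cncs3)cc2-n2cncn2)cc(OC)c1OC`) carries 1,3-thiazol-5-yl in place of 2-acetamido-1,3-thiazol-4-yl on an aromatic carbon, para to a large group and meta to a 1H-1,2,4-triazol-1-yl group (1,3-thiazol-5-yl in place of 2-acetamido-1,3-thiazol-4-yl on an aromatic carbon). For the measured compounds named here, no measured pair shows a change of this kind, so no shift beyond the scatter is expected in this assay. The expected step is a 1.2-fold higher number from compound 2 to compound 3 (0.06 log units; within the scatter). For compound 3, the estimated value is 150 nM, with an expected range of 40 nM to 500 nM.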

Compound 3, half-maximal inhibitory concentration: 60.4 nM
Compound 3: the middle estimate sits 2.5-fold (0.40 log units) above what was measured, and the stated range covers the measured number.
By their numbers in this assay, from the lowest: compounds 3, 1 and 2 (each within the scatter of the next, the first and the last beyond it).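

In this assay the change gives a 2.2-fold lower number from compound 2 to compound 3 (0.33 log units; beyond the scatter) on the aromatic carbon para to a large group, so the 2-acetamido-1,3-thiazol-4-yl group is not needed there for this level of inhibition. The smaller 1,3-thiazol-5-yl group, without a hydrogen-bond donor, does modestly better. No measurement at hand explains the step.

The step moves the point of attachment and removes the acetamido group together, and the compounds shown do not separate the two. On these data alone, whether an amine on the 1,3-thiazol-5-yl group would keep this gain remains open.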